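Hydroxamate series: swapping the aromatic group on compound 3

This account rests on a few compounds, and the source may have more. Where it says the series, first, only, none or still open, it means among the compounds named here.

Values in a functional assay on MDA-MB-231 cells (Homo sapiens) for inhibition, read by MTT assay, with a stated time of 72 h; a lower number here means a stronger inhibitor, a higher number a weaker inhibitor:
- compound 1 `Nc1ncnc2c1c(-c1cnc3[nH]ccc3c1)nn2CCCCCC(=O)NO`: > 100000 nM, a limit of the assay
- compound 2 `Nc1ncnc2c1c(-c1cnc3[nH]ccc3c1)nn2CCCCCCCCCC(=O)NO`: 10100 nM
- compound 3 `Nc1ncnc2c1c(-c1cnc3[nH]ccc3c1)nn2CCCCCCC(=O)NO`: 37700 nM

Compound 3 has the higher of the two true numbers, with a 3.7-fold higher number from compound 2 to compound 3 (0.57 log units; beyond the scatter). Only a limit lies further up, at compound 1.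

Compound 4 `Nc1nc2cc(-c3nn(CCCCCCC(=O)NO)c4ncnc(N)c34)ccc2o1` is still to be measured in this assay. It keeps the chain of compound 3, and 2-amino-1,3-benzoxazol-5-yl enters on the aromatic carbon: a group of 10 heavy atoms (7 carbon, 2 nitrogen, 1 oxygen; one five-membered aromatic ring with 2 hetero atoms, one six-membered aromatic ring of carbon only) in place of a group of 9 heavy atoms (7 carbon, 2 nitrogen; one five-membered aromatic ring with 1 hetero atom, one six-membered aromatic ring with 1 hetero atom), on an aromatic carbon.

All measured steps change the chain and none touches this group: an at least 9.9-fold lower number from compound 1 to compound 2 (0.99 log units; beyond the scatter), an at least 2.6-fold lower number from compound 1 to compound 3 (0.42 log units; beyond the scatter). They offer only a scale of modest steps, and they fix no direction. Compound 3 sits high at 37700 nM, which leaves more room downward, and a lower number is taken as the likelier outcome.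

A modest step is expected, a 3.8-fold lower number from compound 3 to compound 4 (0.58 log units; beyond the scatter), with wide uncertainty.

The estimate for compound 4 is 10000 nM, with an expected range from 1500 nM to 50000 nM.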

Compound 4, half-maximal inhibitory concentration: 8430 nM
Beside the measured number, compound 4's estimate is 1.2-fold (0.07 log units) above it, within the range that was stated.
By their numbers in this assay, from the lowest: compounds 4 and 2 (each within the scatter of the next); then compound 3. At a limit, above all of these: compound 1.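

In this assay, 2-amino-1,3-benzoxazol-5-yl on the aromatic carbon, with the chain of compound 3 kept, gives a 4.5-fold lower number from compound 3 to compound 4 (0.65 log units; beyond the scatter). Among these compounds, this is the first reading at this position, and it shows that the number responds to a change of the aromatic group as well as to the chain, by a modest step. Nothing measured here accounts for this step.

As far as these compounds go, it remains open whether the amine, the ring oxygen or the carbon-only six-membered ring of the new group carries the step; a benzoxazol-5-yl without the amine, or the same group with sulfur in place of the ring oxygen, would separate these. From the compounds shown here alone, it is also open whether the step holds on a longer chain, such as that of compound 2.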